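A few compounds are considered here, and "the series" means these few. Any claim that something is new, unique, unknown or untested is made for them only; others in the source may bear on it.

Measured compounds:
- compound 1, `COc1cc(OCC=C(C)C)ccc1C(=O)/C=C/c1cccnc1`: 22000 nM
- compound 2, `COc1cc(OCC=C(C)C)ccc1C(=O)/C=C/c1ccc(Br)cc1`: 600000 nM
- compound 3, `C#CCOc1ccc(C(=O)/C=C/c2cccnc2)c(OCC#C)c1`: 6000 nM

All three were tested in an ADME assay on Vero cells (Chlorocebus sabaeus) for cytotoxicity, read by resazurin assay, with a stated time of 72 h; on this read-out higher numbers stand for lower toxicity in this test and lower numbers for higher toxicity in this test. Compound 1 gives 22000 nM and compound 2 gives 600000 nM. These two compounds differ in one place only: 4-bromophenyl in place of pyridin-3-yl on a double-bonded chain carbon bound to a double-bonded chain carbon That single change made a large step, a 27-fold higher number from compound 1 to compound 2 (1.44 log units; beyond the scatter), so the toxicity toward these cells fell sharply with the change.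

Compound 3 gives 6000 nM in this assay, which is a lower number than that of compound 1, so compound 3 is the more toxic of the two here. Compound 3 carries the same pyridin-3-yl group as compound 1, but on a different core; the difference between the two cores is not broken down here.

Compound 4, `C#CCOc1ccc(C(=O)/C=C/c2ccc(Br)cc2)c(OCC#C)c1`, has not yet been measured in this assay. It relates to compound 3 exactly as compound 2 relates to compound 1: 4-bromophenyl in place of pyridin-3-yl on a double-bonded chain carbon bound to a double-bonded chain carbon The place of the change is the same, so it is the same change, now made on the core of compound 3.

For the measured compounds named here, the only guide to its size is the earlier step. If the change acts on the core of compound 3 as it did on the core of compound 1, where it gave a 27-fold higher number from compound 1 to compound 2 (1.44 log units; beyond the scatter), a large rise in the number is expected again; but with one prior example and a different core, the size is uncertain. The step expected from compound 3 to compound 4 is a 20-fold higher number from compound 3 to compound 4 (1.30 log units; beyond the scatter). For compound 4 the estimated value in this assay is 120000 nM, with a likely range from 30000 nM to 500000 nM.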

Compound 4, half-maximal cytotoxic concentration: 420000 nM
Compound 4: the middle estimate sits 3.5-fold (0.54 log units) below what was measured; measured number inside the range.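

In this assay, putting 4-bromophenyl in place of pyridin-3-yl on the core of compound 3 gave a 70-fold higher number from compound 3 to compound 4 (1.85 log units; beyond the scatter), so toxicity toward these cells fell sharply here as well. Set beside the earlier step, the change goes the same way on both cores, and its size does not differ beyond what repeated measurements would scatter: the same change on two cores in this assay, a 27-fold higher number (1.44 log units; beyond the scatter) from compound 1 to compound 2 and a 70-fold higher number (1.85 log units; beyond the scatter) from compound 3 to compound 4, 2.6-fold (0.41 log units) apart, within the scatter of two such steps This shows that, on these two cores, the change carried over from one to the other with a similar large effect, but two cores are a small sample, so it does not show that the same would hold on any other core in the series, and it does not explain why the number rises.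

The compounds shown leave open which part of the swap matters, since the ring nitrogen leaves and the bromine enters in the same step; a plain phenyl ring would help to separate the two. From the compounds shown here alone, it also remains open how a phenyl ring carrying chlorine or an amine in place of bromine would behave in this assay.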